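The source may hold more compounds than are shown below. What is called first, only, known or untested is meant among the compounds shown, and "the series" means these compounds.

Measured compounds in a functional assay on HeLa cells (Homo sapiens) for antiproliferative activity, read by CCK-8 assay, with a stated time of 72 h; a higher number here means a weaker inhibitor, a lower number a stronger inhibitor:
- compound 1 `O=C(Nc1cccc(-c2oc3cc(-c4ccc(F)cc4)ccc3c(=O)c2O)c1)c1ccccc1F` — 5630 nM
- compound 2 `COc1ccc(C(=O)Nc2cccc(-c3oc4cc(-c5ccc(F)cc5)ccc4c(=O)c3O)c2)cc1` — 4820 nM
- compound 3 `Cc1cc(C)cc(C(=O)Nc2cccc(-c3oc4cc(-c5ccc(F)cc5)ccc4c(=O)c3O)c2)c1` — 5540 nM

The three measured compounds share one core and differ only in the aryl group on the amide carbonyl carbon. Compound 3 sits among them with no separation: the step of a 1.0-fold lower number from compound 1 to compound 3 (0.01 log units; within the scatter) and the step of a 1.1-fold higher number from compound 2 to compound 3 (0.06 log units; within the scatter) are both within the scatter, as is a 1.2-fold lower number from compound 1 to compound 2 (0.07 log units; within the scatter). Across a 2-fluorophenyl, a 4-methoxyphenyl and a 3,5-dimethylphenyl on that carbonyl carbon, this assay does not move.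

Compound 4 `O=C(Nc1cccc(-c2oc3cc(-c4ccc(F)cc4)ccc3c(=O)c2O)c1)c1ccc([N+](=O)[O-])cc1` is not yet measured. Its change from compound 3 is 4-nitrophenyl in place of 3,5-dimethylphenyl on a carbonyl carbon. All three measured steps bear on it, since each swaps the aryl group at the same carbonyl carbon, and each was within the scatter. A 4-nitrophenyl is a further variation of that same aryl group, so no step beyond the scatter is expected in this assay, in either direction. For compound 4 the estimated step is a 1.1-fold lower number from compound 3 to compound 4 (0.03 log units; within the scatter). Compound 4 is expected to give 5200 nM, with a range from 2600 nM to 10400 nM.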

Compound 4, half-maximal inhibitory concentration: 12300 nM
For compound 4 the middle estimate is 2.4-fold (0.37 log units) below the measured one, and the stated range ends below it.
By their numbers in this assay, from the lowest: compounds 2, 3 and 1 (each within the scatter of the next); then compound 4.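

In this assay the aryl group on the carbonyl carbon is no longer without effect: 4-nitrophenyl gives a 2.2-fold higher number from compound 3 to compound 4 (0.35 log units; beyond the scatter) and also a 2.2-fold higher number from compound 1 to compound 4 (0.34 log units; beyond the scatter) while nitro in place of methoxy on an aromatic carbon gives a 2.6-fold higher number from compound 2 to compound 4 (0.41 log units; beyond the scatter) in the same direction. All three steps lie beyond the scatter but remain modest, which makes compound 4 the weakest of the four and shows that this position does not accept every aryl group alike. No measurement on hand accounts for this rise.

Whether the rise follows the nitro group itself remains open, since the compounds shown include no aryl group carrying an amine, a nitrile or a carboxylic acid on that aromatic carbon. Also open, on these data alone, is how a non-aromatic group on the carbonyl carbon, such as a cyclohexyl ring or a longer alkyl chain, would read in this assay.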